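Replacing the piperidine of compound 1 with an isobutoxy group

A few compounds are considered here, and "the series" means these few. Any claim that something is new, unique, unknown or untested is made for them only; others in the source may bear on it.

Compound 1 `O=C(NCc1ccc(C(F)(F)F)nc1N1CCCCC1)Nc1cccc2c(=O)[nH]ccc12` gives 13.2 nM in an assay on CHO cells for agonist activity at transient receptor potential cation channel subfamily V member 1 (Homo sapiens); a higher number here means that more compound is needed for the effect, a lower number that less compound is needed. Compound 2 `O=C(NCc1ccc(C(F)(F)F)nc1N1CCC(Cc2ccccc2)CC1)Nc1cccc2c(=O)[nH]ccc12` gives 5.81 nM, and the change from compound 1 to compound 2, benzyl in place of hydrogen on a saturated ring carbon, yields a 2.3-fold lower number from compound 1 to compound 2 (0.36 log units; beyond the scatter). Compound 1 thus has the highest number of the two measured compounds.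

Compound 3 `CC(C)COc1nc(C(F)(F)F)ccc1CNC(=O)Nc1cccc2c(=O)[nH]ccc12` carries the change (isobutoxy in place of piperidin-1-yl on an aromatic carbon), on the carbon next to the ring nitrogen. Among the measured compounds shown here, no measured step bears directly on this exchange: the one known step alters a substituent on the piperidine, whereas here the ring itself is swapped for a chain of similar size with one acceptor. For the measured compounds named here, with only that weak guide, the step from compound 1 to compound 3 is expected to be small, a 1.1-fold higher number from compound 1 to compound 3 (0.06 log units; within the scatter), in either direction. Compound 3 is therefore estimated at 15 nM, with a range from 5 nM to 45 nM.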

Compound 3, half-maximal effective concentration: 78.7 nM
For compound 3 the middle estimate is 5.2-fold (0.72 log units) below the measured one; measured number above the stated range.
By their numbers in this assay, from the lowest: compound 2; then compound 1; then compound 3.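

In this assay, isobutoxy in place of piperidin-1-yl gives a 6.0-fold higher number from compound 1 to compound 3 (0.78 log units; beyond the scatter), a step beyond the scatter. The earlier step changed only a substituent on the piperidine, whereas this one shows that the number also responds to the group attached directly to this aromatic carbon, even though the two groups have the same counts of hydrogen-bond donors and acceptors. No measurement shown accounts for the size of this step.

Two things change at once here: the ring is lost, and oxygen replaces nitrogen as the atom joined to the aromatic carbon. The compounds shown leave these two changes unseparated, and a pair such as diethylamino, which keeps the nitrogen without a ring, and cyclohexyloxy, which keeps a ring with oxygen, could tell them apart.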